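Compound 2 to compound 4: swapping methoxy for oxadiazole

The source may report more compounds than this note shows. Statements on the series, on what has been measured and on what is new or still open speak of the compounds shown alone.

Measured in an in vitro ADME assay on microsomes from liver (Homo sapiens) for metabolic stability; on this read-out higher numbers stand for fast clearance and lower numbers for slow clearance:
- compound 1 `CS(=O)(=O)Cc1cccc2c1CCC2c1ncc[nH]1`: < 7 mL.min-1.g-1 (a limit of the assay)
- compound 2 `COCc1cccc2c1CC[C@H]2c1ncc[nH]1`: 12 mL.min-1.g-1
- compound 3 `COCc1c(F)ccc2c1CC[C@H]2c1ncc[nH]1`: 11 mL.min-1.g-1

For the measured compounds named here, compound 2 and compound 3 lie within the scatter of each other and hold the only two true numbers. Still unmeasured, compound 4 `Cc1noc(Cc2cccc3c2CC[C@H]3c2ncc[nH]2)n1` departs from compound 2 as follows: 3-methyl-1,2,4-oxadiazol-5-yl in place of methoxy on a saturated chain carbon bound to an aromatic carbon. Going by the values given here, the one measured step, a 1.1-fold lower number from compound 2 to compound 3 (0.04 log units; within the scatter), is a different change, fluoro in place of hydrogen on an aromatic carbon, and stayed within the scatter. Among the compounds with values here, no measured step replaces methoxy, so no direction can be argued and no shift beyond the scatter is expected in this assay. The expected step is a 1.1-fold lower number from compound 2 to compound 4 (0.04 log units; within the scatter). For compound 4 the estimate is 11 mL.min-1.g-1, with an expected range of 7 mL.min-1.g-1 to 22 mL.min-1.g-1.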

Compound 4, intrinsic clearance in microsomes in the Homo sapiens assay: 44 mL.min-1.g-1
Beside the measured number, compound 4's estimate is 4.0-fold (0.60 log units) below it; the measured number lies above the stated range.
By their numbers in the Homo sapiens assay, from the lowest: compounds 3 and 2 (each within the scatter of the next); then compound 4. At a limit, below all of these: compound 1.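

In the Homo sapiens assay compound 2 gives 12 mL.min-1.g-1 and compound 4 gives 44 mL.min-1.g-1. In the Homo sapiens assay the group on a saturated chain carbon bound to an aromatic carbon matters: 3-methyl-1,2,4-oxadiazol-5-yl in place of methoxy gives a 3.7-fold higher number from compound 2 to compound 4 (0.56 log units; beyond the scatter) and is the first step beyond the scatter in the compounds shown. In a physicochemical assay for lipophilicity, at pH 7.4 (a higher number here means a more lipophilic compound, a lower number a more polar compound), compound 2 gives 1.8 and compound 4 gives 2. In the physicochemical assay the same change gives a number 0.20 log units higher from compound 2 to compound 4 (within the scatter) and so does not follow the larger step. Nothing shown accounts for that larger step.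

Open, from the compounds shown here alone, is whether a nitrile or a primary amide in place of methoxy at this place stays close to compound 2 or moves with compound 4.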